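From Anilino to 3-Acetylphenyl on a Shared Core

The source may hold more compounds than are shown below. What is called first, only, known or untested is meant among the compounds shown, and "the series" means these compounds.

In an ADME assay on WI-38 cells (Homo sapiens) for cytotoxicity, read by sulforhodamine B assay, with a stated time of 24 h (a lower number here means a stronger inhibitor, a higher number a weaker inhibitor), compound 1 (`N/N=C1\C(=O)Nc2ccc(S(=O)(=O)N3CCOCC3)cc21`) gives 391000 nM and compound 2 (`O=C1Nc2ccc(S(=O)(=O)N3CCOCC3)cc2/C1=N/Nc1ccccc1`) gives 262000 nM on the same read-out. These two numbers lie within the scatter of each other, so compound 2 does not stand apart from compound 1. Among the compounds with values here, the one measured step between them is a 1.5-fold lower number from compound 1 to compound 2 (0.17 log units; within the scatter) for phenyl in place of hydrogen on an amine nitrogen.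

Compound 3 (`CC(=O)c1cccc(/N=C2\C(=O)Nc3ccc(S(=O)(=O)N4CCOCC4)cc32)c1`) keeps the shared core and differs from compound 2 by 3-acetylphenyl in place of anilino on a double-bonded nitrogen in one place, with 3-acetylphenyl in place of anilino on a double-bonded nitrogen. Within the data shown here, only that measured step bears on this change, and it offers limited guidance. Among the measured compounds shown here, compound 2 arose from compound 1 with a 1.5-fold lower number from compound 1 to compound 2 (0.17 log units; within the scatter) as the whole move, and no measured compound carries an acetyl group, so the data give no direction. No step beyond the scatter is therefore expected in this assay for this change. The expected move is a 1.2-fold lower number from compound 2 to compound 3 (0.08 log units; within the scatter) as estimated here. Compound 3 is estimated at 220000 nM with an expected range from 90000 nM to 450000 nM in this measurement.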

Compound 3, half-maximal inhibitory concentration: 177000 nM
Compound 3: middle estimate off by 1.2-fold (0.09 log units), on the high side, within the range that was stated.
By their numbers in this assay, from the lowest: compounds 3, 2 and 1 (each within the scatter of the next, the first and the last beyond it).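

In this assay, 3-acetylphenyl in place of anilino on a double-bonded nitrogen gives a 1.5-fold lower number from compound 2 to compound 3 (0.17 log units; within the scatter), so a group with 0 hydrogen-bond donors can replace anilino here without the number leaving the scatter. Set against the amino group of compound 1, the same position gives a 2.2-fold lower number from compound 1 to compound 3 (0.34 log units; beyond the scatter), the first step in this series to lie beyond the scatter, although it is only a modest one, and compound 2 stays within the scatter of both neighbours, so the series offers a difference only between its two end members. Nothing available accounts for either step.

From the compounds shown here alone, it remains open whether the acetyl group contributes anything of its own or whether the phenyl ring that carries it is enough, which a plain phenyl on the double-bonded nitrogen would help to separate. Going by these compounds, how a carboxylic acid, an amine or a longer chain in place of the acetyl group would read in this assay also remains open, as does whether any such group could move the number further than this modest step.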